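Replacing 4-methylphenyl with 3-chlorophenyl on an aromatic nitrogen

This account rests on a few compounds, and the source may have more. Where it says the series, first, only, none or still open, it means among the compounds named here.

In a functional assay on MCF7 cells (Homo sapiens) for inhibition, read by MTT assay, with a stated time of 72 h (a lower number here means a stronger inhibitor, a higher number a weaker inhibitor), compound 1 `Cc1cc2occ(-c3nc(-c4ccccc4)c(-c4ccccc4)n3-c3cccc([N+](=O)[O-])c3)c(=O)c2cc1Cl` gives 1560 nM as its reading. Compound 2 `Cc1ccc(-n2c(-c3coc4cc(C)c(Cl)cc4c3=O)nc(-c3ccccc3)c2-c2ccccc2)cc1` gives 12500 nM and so holds the higher number of the two, which makes it the weaker inhibitor. Compound 3 `Cc1cc2occ(-c3nc(-c4ccccc4)c(-c4ccccc4)n3-c3cccc(Cl)c3)c(=O)c2cc1Cl` has not been measured yet. It carries 3-chlorophenyl in place of the 4-methylphenyl of compound 2 on an aromatic nitrogen (3-chlorophenyl in place of 4-methylphenyl on an aromatic nitrogen). For the measured compounds named here, only one measured step bears on this swap (an 8.0-fold higher number from compound 1 to compound 2 (0.90 log units; beyond the scatter)), a modest change beyond the scatter, with 4-methylphenyl in place of 3-nitrophenyl on that same nitrogen. The incoming group again has its substituent numbered 3, so a partial return towards compound 1 (1560 nM) is expected, though chlorine is not a nitro group. The expected change is a lower number of modest size (a 3.6-fold lower number from compound 2 to compound 3 (0.55 log units; beyond the scatter)). Compound 3 is estimated at 3500 nM with an expected range (1200 nM to 10000 nM).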

Compound 3, half-maximal inhibitory concentration: 6250 nM
Compound 3: the middle estimate sits 1.8-fold (0.25 log units) below what was measured; low and high end bracket the measured number.
By their numbers in this assay, from the lowest: compound 1; then compounds 3 and 2 (each within the scatter of the next).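

In this assay, swapping 4-methylphenyl for 3-chlorophenyl on the aromatic nitrogen makes no clear difference (a 2.0-fold lower number from compound 2 to compound 3 (0.30 log units; within the scatter)), so these two groups cannot be told apart here even though their substituents differ in kind and ring number. Chloro in place of nitro on the same phenyl ring, by contrast, gives a change beyond the scatter (a 4.0-fold higher number from compound 1 to compound 3 (0.60 log units; beyond the scatter)), which shows that a substituent numbered 3 does not by itself match compound 1, and compound 1 remains the strongest inhibitor of the three. Nothing available explains why the nitro compound stands apart.

The effects of substituent type and ring number remain tangled, and 4-chlorophenyl or 3-methylphenyl would separate them. Going by these compounds, how a plain phenyl, or a phenyl carrying an amine or a carboxylic acid, would behave on this nitrogen also remains open.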